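Methoxyethyl Amide Replaces Propargyl Amide on the Shared Core

The source may hold more compounds than are shown below. What is called first, only, known or untested is meant among the compounds shown, and "the series" means these compounds.

Measured compounds:
compound 1 `C#CCNC(=O)C[C@H](NC(=O)c1ccc(C#Cc2ccccc2)cc1)C(=O)NO` — 3
compound 2 `O=C(N[C@@H](CO)C(=O)NO)c1ccc(C#Cc2ccccc2)cc1` — 2

Compound 1 `C#CCNC(=O)C[C@H](NC(=O)c1ccc(C#Cc2ccccc2)cc1)C(=O)NO` stands highest of the two compounds in a physicochemical assay for lipophilicity (on this read-out lower numbers stand for lower lipophilicity and higher numbers for higher lipophilicity), at 3. Compound 2 `O=C(N[C@@H](CO)C(=O)NO)c1ccc(C#Cc2ccccc2)cc1` gives 2, so that a number 1.00 log units lower from compound 1 to compound 2 (beyond the scatter). Compound 3 `COCCNC(=O)C[C@H](NC(=O)c1ccc(C#Cc2ccccc2)cc1)C(=O)NO` differs from compound 1 by methoxymethyl in place of ethynyl on a saturated chain carbon bound to an amide-type nitrogen. Among the measured compounds shown here, no measured step removes ethynyl or adds methoxymethyl; the step from compound 1 to compound 2 alters a different part of the chain and bears on compound 3 only loosely. A small step is therefore expected for compound 3, a number 0.20 log units lower from compound 1 to compound 3 (within the scatter), and its value is estimated at 2.8, within 2.3 to 3.3.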

Compound 3, distribution coefficient: 2
Compound 3: the middle estimate sits 0.80 log units above what was measured; measured number below the stated range.
By their numbers in this assay, from the lowest: compounds 2 and 3 (each within the scatter of the next); then compound 1.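

The change from propargyl to 2-methoxyethyl on this amide is not a silent one in this assay, with a number 1.00 log units lower from compound 1 to compound 3 (beyond the scatter). Two quite different changes to the chain of compound 1 thus end at the same printed number, with no change at the digits printed from compound 2 to compound 3 (within the scatter). Nothing at hand explains this result. On these data alone, it remains open whether the step comes from losing the ethynyl or from gaining the methoxymethyl. As far as these compounds go, how an amine, a carboxylic acid or a longer chain at this position would read also remains open.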